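This account rests on a few compounds, and the source may have more. Where it says the series, first, only, none or still open, it means among the compounds named here.

Measured in a functional assay on SNB-75 cells (Homo sapiens) for inhibition, read by colorimetric assay and sulforhodamine B assay, with a stated time of 48 h; on this read-out higher numbers stand for weaker inhibition of growth and lower numbers for stronger inhibition of growth:
- Compound 1 `CCCCCCCCCCCC[C@@H](O)[C@H]1CC[C@H]([C@H](O)CCCCCCCCCCNC(=O)c2cccs2)O1`: 3390 nM
- Compound 2 `CCCCCCCCCCCC[C@@H](O)[C@H]1CC[C@H]([C@H](O)CCCCCCCCCCNC(=O)c2ccco2)O1`: 100000 nM
- Compound 3 `CCCCCCCCCCCC[C@@H](O)[C@H]1CC[C@H]([C@H](O)CCCCCCCCCCNC(=O)c2ccoc2)O1`: 100000 nM

Compound 2 and compound 3 share the highest number of the series, and compound 3 sits at 100000 nM. The step between them is no change at the digits printed from compound 2 to compound 3 (within the scatter). Compound 1 lies well apart from both.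

The next compound, compound 4 `CCCCCCCCCCCC[C@@H](O)[C@H]1CC[C@H]([C@H](O)CCCCCCCCCCNC(=O)c2cncs2)O1`, differs from compound 3 as follows: 1,3-thiazol-5-yl in place of furan-3-yl on a carbonyl carbon. In words, it carries 1,3-thiazol-5-yl in place of furan-3-yl on a carbonyl carbon.

For the measured compounds named here, no compound with this ring has been measured, so the closest guide is the thiophen-2-yl amide. Replacing that ring with a furan gave a 29-fold higher number from compound 1 to compound 2 (1.47 log units; beyond the scatter) and a 29-fold higher number from compound 1 to compound 3 (1.47 log units; beyond the scatter), both large. The two furan isomers themselves gave no separation. Like thiophen-2-yl, 1,3-thiazol-5-yl contains sulfur, so some recovery towards compound 1 at 3390 nM seems likely. However, this expectation rests on that single compound, and the ring also differs from thiophen-2-yl.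

A large step to a lower number in this assay is therefore expected, though probably not the full distance. The estimated change is a 10-fold lower number from compound 3 to compound 4 (1.00 log units; beyond the scatter). For compound 4 the expected value is 10000 nM, with an estimated range from 2500 nM to 100000 nM.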

Compound 4, concentration for 50% growth inhibition: 100000 nM
Compound 4: the middle estimate sits 10-fold (1.00 log units) below what was measured; low and high end bracket the measured number.
By their numbers in this assay, from the lowest: compound 1; then compounds 2, 3 and 4 (each within the scatter of the next).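

In this assay, a sulfur-containing ring on the carbonyl carbon is not enough to give the level of compound 1: there is a 29-fold higher number from compound 1 to compound 4 (1.47 log units; beyond the scatter), a step of the same size as those to the two furans. Against those furans, 1,3-thiazol-5-yl stands level, with no change at the digits printed from compound 3 to compound 4 (within the scatter) and no change at the digits printed from compound 2 to compound 4 (within the scatter), so among the four amides only the thiophen-2-yl group of compound 1 stands apart, while compounds 2, 3 and 4 do not separate from one another. The information at hand offers no explanation for why the 1,3-thiazol-5-yl amide falls with the furans rather than with the thiophen-2-yl amide.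

From the compounds shown here alone, it remains open whether the level of compound 1 is specific to thiophen-2-yl, a question that a thiophen-3-yl or phenyl group on the same carbonyl carbon would help to answer. Going by these compounds, all four compounds also share the same core and the same chains, so whether a shorter or longer chain between the core and the amide nitrogen would change the gap between these rings also stays open.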